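The source may report more compounds than this note shows. Statements on the series, on what has been measured and on what is new or still open speak of the compounds shown alone.

The compounds measured so far, with their values in a functional assay on cells (T-cell, Homo sapiens) for inhibition; on this read-out lower numbers stand for stronger inhibition and higher numbers for weaker inhibition:

- compound 1, `COc1ccc(-c2cnc3nc(N)nc(NC4CCCC4)c3n2)cc1OC`: 800 nM
- compound 2, `COc1ccc(-c2cnc3nc(N)nc(N4CCN(C(=O)Nc5ccccc5)CC4)c3n2)cc1OC`: 3.4 nM
- compound 3, `COc1ccc(-c2cnc3nc(N)nc(N4CCN(Cc5ccccc5)CC4)c3n2)cc1OC`: 900 nM

Compound 3 gives the highest of the three numbers in this assay. Its nearest neighbour is compound 1, whose value lies within the scatter of that of compound 3, so nothing separates the two. Among the compounds with values here, compound 2 stands far lower; the one measured step, a 260-fold higher number from compound 2 to compound 3 (2.42 log units; beyond the scatter), comes from the change of benzyl in place of phenylcarbamoyl on an amine nitrogen in a ring.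

Compound 4, `COc1ccc(-c2cnc3nc(N)nc(N4CCN(Cc5ccc(C(C)(C)C)cc5)CC4)c3n2)cc1OC`, differs from compound 3 by tert-butyl in place of hydrogen on an aromatic carbon. Within the data shown here, no measured step touches a group on that aromatic ring, and the step from compound 2 to compound 3 concerns a different position and a different kind of group, so it gives no guide to the size or direction here. With nothing in the data pointing either way, the expected step is no change at the digits printed from compound 3 to compound 4 (within the scatter), that is, none beyond the scatter. Compound 4 is therefore estimated at 900 nM in this assay, with a range from 250 nM to 3500 nM.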

Compound 4, half-maximal inhibitory concentration: 4300 nM
Beside the measured number, compound 4's estimate is 4.8-fold (0.68 log units) below it, outside the stated range (above it).
By their numbers in this assay, from the lowest: compound 2; then compounds 1 and 3 (each within the scatter of the next); then compound 4.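

The benzyl ring of compound 3 is not indifferent to substitution: in this assay, tert-butyl in place of hydrogen on an aromatic carbon gives a 4.8-fold higher number from compound 3 to compound 4 (0.68 log units; beyond the scatter), so this position responds, and the one group shown here moves the number upward. The comparison with the phenylcarbamoyl compound widens to a 1300-fold higher number from compound 2 to compound 4 (3.10 log units; beyond the scatter), so 4-(tert-butyl)benzyl recovers nothing of what plain benzyl lost on that ring nitrogen. Nothing available here bears on the reason for this rise.

From the compounds shown here alone, it remains open whether the rise belongs to tert-butyl itself or to any group at this place, since a methyl, a methoxy or a carboxylic acid on the same carbon could read differently. Also open, going by these compounds, is whether tert-butyl would do the same on the phenyl of the phenylcarbamoyl group in compound 2.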